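Swapping chloro for trifluoromethyl on the shared core

The compounds below may be only part of what the source reports. "The series", "measured", "known", "first", "only" and "open" are said of these compounds alone.

Of the compounds shown here, three sharing one core have been measured in an assay on cells for binding affinity to metabotropic glutamate receptor 2 (Homo sapiens), read by scintillation proximity assay; on this read-out higher numbers stand for weaker binding and lower numbers for tighter binding. Going by the values given here, compound 1 `CC(C)Nc1ccc(-c2ccn3c(CC4CC4)nnc3c2C(F)(F)F)cc1Cl` gives 3.4 nM in this assay, and compound 2 `FC(F)(F)c1c(-c2ccc(OC3CCOCC3)c(Cl)c2)ccn2c(CC3CC3)nnc12` gives 12.3 nM; the one measured step, a 3.6-fold higher number from compound 1 to compound 2 (0.56 log units; beyond the scatter), concerns only the side group. Compound 3 `Clc1cc(-c2ccn3c(CC4CC4)nnc3c2Cl)ccc1NC1CCOCC1` gives 19.5 nM, which lies beyond the scatter from compound 1 but within the scatter of compound 2.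

Compound 4 `FC(F)(F)c1c(-c2ccc(NC3CCOCC3)c(Cl)c2)ccn2c(CC3CC3)nnc12` differs from compound 3 by trifluoromethyl in place of chloro on an aromatic carbon. Among the compounds with values here, no measured step bears on this change directly: compound 1 and compound 2 already carry the trifluoromethyl group on the core, while compound 3 is the only one with chloro there, and each also differs in the side group. Because compound 2 gives 12.3 nM with the trifluoromethyl core and an oxan-4-yl side group, compound 4 is expected to land near that range, with a step of a 2.0-fold lower number from compound 3 to compound 4 (0.29 log units; within the scatter) that may stay within the scatter. The estimate for compound 4 is 10 nM, between 3 nM and 30 nM.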

Compound 4, dissociation constant: 3.8 nM
For compound 4 the middle estimate is 2.6-fold (0.42 log units) above the measured one, and the stated range covers the measured number.
By their numbers in this assay, from the lowest: compounds 1 and 4 (each within the scatter of the next); then compounds 2 and 3 (each within the scatter of the next).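

In this assay, trifluoromethyl in place of chloro on the aromatic carbon of the shared core can now be read directly with the (oxan-4-yl)amino side group held constant (a 5.1-fold lower number from compound 3 to compound 4 (0.71 log units; beyond the scatter)), a modest step beyond the scatter. With trifluoromethyl on the core, (oxan-4-yl)amino in place of (oxan-4-yl)oxy also gives a modest step beyond the scatter (a 3.2-fold lower number from compound 2 to compound 4 (0.51 log units; beyond the scatter)), whereas oxan-4-yl in place of isopropyl on the nitrogen stays within the scatter (a 1.1-fold higher number from compound 1 to compound 4 (0.05 log units; within the scatter)). No evidence is available on what lies behind these steps.

On these data alone, whether the step from chloro to trifluoromethyl has the same size with the isopropylamino or (oxan-4-yl)oxy side groups remains open. Also open, as far as these compounds go, is how a nitrile, a methyl or a methoxy group would compare at this position on the core.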